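Cyanoguanidine in place of isothiourea on the six-bond chain

The source may report more compounds than this note shows. Statements on the series, on what has been measured and on what is new or still open speak of the compounds shown alone.

Compound 1 `CC/N=C(\S)NCCCCCCn1nc(-c2ccccc2)ccc1=O` gives -5.6% in a functional assay on the whole organism with Rattus norvegicus as the target, at a dose of 100 mg/kg (a higher number here means more inhibition at the dose given (going by the name of the read-out), a lower number less inhibition), the lowest of the three numbers seen so far. Compound 2 `CN(C)/C(=N/CCCCn1nc(-c2ccccc2)ccc1=O)NC#N` gives 80.7% and compound 3 `C/N=C(\NC#N)NCCCCn1nc(-c2ccccc2)ccc1=O` gives 79% in this assay. The steps are a number 86.3 percentage points higher from compound 1 to compound 2 (beyond the scatter) and a number 84.6 percentage points higher from compound 1 to compound 3 (beyond the scatter), while a number 1.7 percentage points lower from compound 2 to compound 3 (within the scatter). Compound 4 `CN(C)/C(=N/CCCCCCn1nc(-c2ccccc2)ccc1=O)NC#N` differs from compound 1 as follows: a group of 8 heavy atoms (4 carbon, 4 nitrogen; no ring) in place of a group of 6 heavy atoms (3 carbon, 2 nitrogen, 1 sulfur; no ring), on a saturated chain carbon, six bonds along the chain from an aromatic nitrogen. Going by the values given here, the entering group is the one found in compound 2, and both measured steps away from compound 1 were large and upward, so a large rise is expected here too, although the change sits on the longer chain, for which no comparison exists. For compound 4 an inhibition of 72% is estimated, between 45% and 92%, a step of a number 77.6 percentage points higher from compound 1 to compound 4 (beyond the scatter) expected from compound 1.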

Compound 4, a percentage reported as inhibition, in the whole organism at one dose (the size of the read-out at that dose, not a potency): 58.4%
Beside the measured number, compound 4's estimate is 13.6 percentage points above it; the measured number falls inside the stated range.
By their numbers in this assay, from the lowest: compound 1; then compound 4; then compounds 3 and 2 (each within the scatter of the next).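

On the six-bond chain, cyanoguanidine in place of isothiourea gives a number 64 percentage points higher from compound 1 to compound 4 (beyond the scatter) in this assay, so a large rise is now seen within a single chain length. With the same dimethyl-substituted cyanoguanidine, compound 4 gives 58.4% and compound 2 gives 80.7%, so the read-out also differs with chain length. No evidence on the cause of either difference is available. Open, on these data alone, are how an isothiourea behaves on the four-bond chain and how the cyanoguanidine behaves on a longer chain.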